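Swapping a methoxy for a chloro on the sulfonyl aryl ring

A few compounds are considered here, and "the series" means these few. Any claim that something is new, unique, unknown or untested is made for them only; others in the source may bear on it.

Measured so far:
compound 1, `COc1ccc2ncc(S(=O)(=O)c3cccc(C#N)c3)c(N3CCC(C)CC3)c2c1`, 90%
compound 2, `COc1ccc2ncc(S(=O)(=O)c3ccc(C)c(F)c3)c(N3CCC(C)CC3)c2c1`, 73%
compound 3, `COc1cccc(S(=O)(=O)c2cnc3ccc(OC)cc3c2N2CCC(C)CC2)c1`, 0%

Three compounds share one core and differ only in the ring attached to the sulfonyl sulfur. In an assay on isolated protein for displacement of a labelled ligand from metabotropic glutamate receptor 5 (Homo sapiens), with a stated time of 60 min, tested at 1 uM (a lower number here means less inhibition, a higher number more inhibition at the concentration tested (going by the name of the read-out)), compound 1 gives 90%, compound 2 gives 73%, and compound 3 gives 0%. Compound 3 therefore stands lowest of the three, with a number 73 percentage points lower from compound 2 to compound 3 (beyond the scatter) and a number 90 percentage points lower from compound 1 to compound 3 (beyond the scatter), both well beyond the scatter.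

Compound 4, `COc1ccc2ncc(S(=O)(=O)c3cccc(Cl)c3)c(N3CCC(C)CC3)c2c1`, has not yet been measured. It differs from compound 3 in one place: chloro in place of methoxy on an aromatic carbon.

Among the compounds with values here, two measured steps bear on this. The step of a number 90 percentage points lower from compound 1 to compound 3 (beyond the scatter) shows that replacing a cyano by a methoxy at this position wipes out nearly all of the read-out; the step of a number 73 percentage points lower from compound 2 to compound 3 (beyond the scatter) shows the same for a 3-fluoro-4-methylphenyl going to 3-methoxyphenyl. The methoxy group is the one feature tied to the very low value of compound 3, and compound 4 removes it. Chloro has not been tested here, so the size of the recovery is uncertain, but a large upward step is expected: a number 70 percentage points higher from compound 3 to compound 4 (beyond the scatter). Compound 4 is estimated at 70%, between 35% and 95%.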

Compound 4, a percentage reported as inhibition, at one concentration (the size of the read-out at that concentration, not a potency): -3%
For compound 4 the middle estimate is 73 percentage points above the measured one; measured number below the stated range.
By their numbers in this assay, from the lowest: compounds 4 and 3 (each within the scatter of the next); then compound 2; then compound 1.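

Swapping methoxy for chloro on this aromatic carbon, the step of a number 3 percentage points lower from compound 3 to compound 4 (within the scatter) in this assay does not bring the read-out back, so removing the methoxy alone is not enough and compound 3 no longer stands apart as a single poor case. On the same carbon, the step of a number 93 percentage points lower from compound 1 to compound 4 (beyond the scatter) marks chloro in place of cyano as a large loss, and with compound 3 this shows that two different groups at this place fall far short of the nitrile of compound 1, while the step of a number 76 percentage points lower from compound 2 to compound 4 (beyond the scatter) shows that the 3-chlorophenyl ring also falls far short of the 3-fluoro-4-methylphenyl ring of compound 2. Nothing measured here explains why these single changes have such large effects.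

As far as these compounds go, how an amine, a carboxylic acid or an amide on this aromatic carbon would read remains open. Also open, from the compounds shown here alone, is whether the fluoro or the methyl of compound 2 carries its read-out, as the two groups appear together on its ring.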